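A few compounds are considered here, and "the series" means these few. Any claim that something is new, unique, unknown or untested is made for them only; others in the source may bear on it.

Compound 3 `O=C(NS(=O)(=O)CCNC(=O)C1CC1)c1ccc(Nc2nc(NC3(c4ccc(Cl)cc4)CC3)nc(OCC(F)(F)F)n2)cc1` gives 1 nm/s in a physicochemical assay for permeability, using PAMPA, at pH 7.4 (on this read-out higher numbers stand for higher permeability and lower numbers for lower permeability), the lowest of the three measured numbers. Compound 1 `O=C(NS(=O)(=O)c1ccc(F)cc1)c1ccc(Nc2nc(NC3(c4ccc(Cl)cc4)CC3)nc(OCC(F)(F)F)n2)cc1` gives 193 nm/s in this assay, and compound 2 `CC(C)NCCS(=O)(=O)NC(=O)c1ccc(Nc2nc(NC3(c4ccc(Cl)cc4)CC3)nc(OCC(F)(F)F)n2)cc1` gives 45 nm/s in this assay. Compound 3 stands apart from both through the steps of a 190-fold lower number from compound 1 to compound 3 (2.29 log units; beyond the scatter) and a 45-fold lower number from compound 2 to compound 3 (1.65 log units; beyond the scatter), while the remaining step, a 4.3-fold lower number from compound 1 to compound 2 (0.63 log units; beyond the scatter), is only modest. Compound 4 `CC(C)(C)CNCCS(=O)(=O)NC(=O)c1ccc(Nc2nc(NC3(c4ccc(Cl)cc4)CC3)nc(OCC(F)(F)F)n2)cc1` differs from compound 3 by neopentyl in place of cyclopropylcarbonyl on an amine nitrogen. The step that bears on this is the one in which cyclopropylcarbonyl replaced isopropyl on the same nitrogen, and it was large; compound 4 undoes that kind of change, so a large rise is expected in this assay, back towards the region of compound 2. Compound 4 is therefore expected to give 40 nm/s, between 10 nm/s and 130 nm/s, an expected step of a 40-fold higher number from compound 3 to compound 4 (1.60 log units; beyond the scatter).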

Compound 4, apparent permeability: 651 nm/s
Compound 4: middle estimate off by 16-fold (1.21 log units), on the low side, outside the stated range (above it).
By their numbers in this assay, from the lowest: compound 3; then compound 2; then compound 1; then compound 4.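

In this assay, the group on this amine nitrogen matters even among groups without a carbonyl: neopentyl in place of cyclopropylcarbonyl gives a 650-fold higher number from compound 3 to compound 4 (2.81 log units; beyond the scatter), and neopentyl in place of isopropyl still gives a 14-fold higher number from compound 2 to compound 4 (1.16 log units; beyond the scatter). With neopentyl, the 2-(neopentylamino)ethyl chain also surpasses 4-fluorophenyl on the sulfonyl sulfur, giving a 3.4-fold higher number from compound 1 to compound 4 (0.53 log units; beyond the scatter), a reversal of the direction seen with isopropyl. No measurement shown explains these differences.

On these data alone, it remains open whether the number follows the size or the branching of the group, which an n-pentyl chain or a cyclohexylmethyl group on this nitrogen would address. As far as these compounds go, a tertiary amine at this position also remains open.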